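Cytotoxicity in the hydrazone series: methyl for methoxy

A few compounds are considered here, and "the series" means these few. Any claim that something is new, unique, unknown or untested is made for them only; others in the source may bear on it.

Measured so far:
Compound 1, `O=C(NN=C1CC(c2ccccc2)NC(c2ccccc2)C1)c1ccccc1`: > 400000 nM in a toxicity assay on BJ cells (Homo sapiens) for cytotoxicity, read by MTT assay, with a stated time of 24 h; on this read-out lower numbers stand for stronger inhibition and higher numbers for weaker inhibition
Compound 2, `COc1ccc(C(=O)NN=C2CC(c3ccccc3)NC(c3ccccc3)C2)cc1`: > 400000 nM in this assay

In this assay compound 1 gives only a limit, > 400000 nM. In this assay compound 2 likewise gives only a limit, > 400000 nM. Among the compounds with values here, the one step between measured compounds, a step that the two limits leave unreadable from compound 1 to compound 2, therefore cannot be sized. Compound 2 stands at the limit of the read-out together with compound 1 (the limit of > 400000 nM in this assay, at which 2 of the 2 values shown sit); no number places it relative to any other compound.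

Compound 3, `Cc1ccc(C(=O)NN=C2CC(c3ccccc3)NC(c3ccccc3)C2)cc1`, has not been measured. It differs from compound 2 by methyl in place of methoxy on an aromatic carbon. Within the data shown here, no measured step bears on this change beyond the unreadable step from compound 1 to compound 2, so nothing sets an expected direction; both measured compounds sit at the limit, and a step beyond the scatter in either direction is not supported. The expected step that the limit leaves unreadable from compound 2 to compound 3 is accordingly none beyond the scatter, with the read-out most likely again reported only as a limit. Compound 3 is estimated at 600000 nM in this assay, with a range from 200000 nM to 2000000 nM.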

Compound 3, half-maximal inhibitory concentration: > 400000 nM
Compound 3: no number, only a limit (the forecaster's own chance of this, stated with the estimate: 85%); the middle value does not contradict the limit.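

In this assay compound 3 gives > 400000 nM, a limit and not a number. No step can be read among compound 1, compound 2 and compound 3, which all sit at the same limit: the limit of > 400000 nM in this assay, at which 3 of the 3 values shown sit.

The compounds shown leave open whether methoxy, methyl or hydrogen at this aromatic carbon makes any difference to cytotoxicity, and what actual value any of the three compounds has.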